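The compounds below may be only part of what the source reports. "The series", "measured", "known", "first", "only" and "open" are said of these compounds alone.

Compound 1, `COc1cc(SC)nc(NC(=S)NC(=O)c2c(-c3ccc(Cl)cc3Cl)noc2C)n1`, in a functional assay on the whole organism (strain L.) for inhibition, with Echinochloa crus-galli as the target, with a stated time of 72 h, tested at 10 mg/L (a lower number here means less inhibition of growth, a higher number more inhibition of growth at the concentration tested), gives 19.3%.
Compound 2, `COc1cc(Cl)nc(NC(=S)NC(=O)c2c(-c3ccc(Cl)cc3Cl)noc2C)n1`, in this assay gives 18.5%.
Compound 3, `COc1cc(Cl)nc2n/c(=N/C(=O)c3c(-c4ccc(Cl)cc4Cl)noc3C)sn12`, in this assay gives 10.8%.

Compound 4, `COc1cc(SC)nc2n/c(=N/C(=O)c3c(-c4ccc(Cl)cc4Cl)noc3C)sn12`, has not yet been measured. The change from compound 2 to compound 1 is methylsulfanyl in place of chloro on an aromatic carbon, and it made a step of a number 0.8 percentage points higher from compound 2 to compound 1 (within the scatter). The core of compound 3 differs from that of compound 2, but the difference between the two cores is not broken down here; the numbers of compound 3, compound 2 and compound 1 all lie within the scatter of one another. Compound 4 is reached from compound 3 by methylsulfanyl in place of chloro on an aromatic carbon, the same kind of change, though the surroundings differ: in compound 3 the ring is part of a fused or bridged system of two rings, meta and para to a fused ring, whereas in compound 2 it is meta to a large group. Since the earlier step of a number 0.8 percentage points higher from compound 2 to compound 1 (within the scatter) was within the scatter, the step from compound 3 to compound 4 is expected to be a number 1.2 percentage points higher from compound 3 to compound 4 (within the scatter), again small. Compound 4 is therefore estimated at 12%, roughly from 4% to 22%.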

Compound 4, percent growth inhibition at one concentration: 21.4%
The estimate for compound 4 lay 9.4 percentage points below the measured number; measured number inside the range.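

In this assay, methylsulfanyl in place of chloro on an aromatic carbon gives a number 10.6 percentage points higher from compound 3 to compound 4 (beyond the scatter), while the same change on the other core gives a number 0.8 percentage points higher from compound 2 to compound 1 (within the scatter). Within the data shown here, although only the first of these steps lies beyond the scatter, the two cannot be told apart when set side by side: the same change on two cores in this assay, a number 0.8 percentage points higher (within the scatter) from compound 2 to compound 1 and a number 10.6 percentage points higher (beyond the scatter) from compound 3 to compound 4, 9.8 percentage points apart, within the scatter of two such steps The pair therefore does not show that the core alters what this change does, nor does it prove that the change carries over unaltered, since each core supplies only a single step, read at one concentration on one organism.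

The compounds shown carry only chloro or methylsulfanyl at this place, so how an amine or a longer sulfur-linked chain there would read in this assay stays open. Going by these compounds, the methoxy group and the side chain are also the same in all four compounds, so whether the step holds when either of them is replaced is likewise open.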